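Removing the nitrile from an inactive pair in a cytotoxicity screen

The compounds below may be only part of what the source reports. "The series", "measured", "known", "first", "only" and "open" are said of these compounds alone.

Compound 1 `COc1ccc2c(-c3cc(C(F)(F)F)c(C#N)c(-c4cn(S(=O)(=O)c5ccc(C)cc5)c5cc(OC)ccc45)n3)cn(S(=O)(=O)c3ccc(C)cc3)c2c1` was examined in a functional assay on A549 cells (Homo sapiens) for cytotoxicity; on this read-out lower numbers stand for stronger inhibition and higher numbers for weaker inhibition. In this assay compound 1 gives > 100000 nM, which is a limit of the assay rather than a measured number. Compound 2 `COc1ccc2c(c1)c(-c1cc(C(F)(F)F)ccn1)cn2S(=O)(=O)c1ccc(C)cc1`, a smaller relative, was run in this assay too. In this assay compound 2 gives > 100000 nM, again a limit and not a number. Both results rest at the limit of > 100000 nM in this assay, at which 2 of the 2 values shown sit. Compound 3 `COc1ccc2c(-c3cc(C(F)(F)F)cc(-c4cn(S(=O)(=O)c5ccc(C)cc5)c5cc(OC)ccc45)n3)cn(S(=O)(=O)c3ccc(C)cc3)c2c1` has not yet been measured; compared with compound 1 its change is hydrogen in place of cyano on an aromatic carbon. Within the data shown here, no step between two measured compounds is available to size this change. With both measured relatives at the limit, the step is expected to be a step that the limit leaves unreadable from compound 1 to compound 3, nothing beyond the usual scatter. Compound 3 is therefore estimated at 150000 nM, within a range from 50000 nM to 500000 nM, and most likely it will again be reported only as a limit.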

Compound 3, half-maximal inhibitory concentration: 1700 nM
For compound 3 the middle estimate is 88-fold (1.95 log units) above the measured one; the measured number lies below the stated range.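

Replacing the nitrile with hydrogen on this aromatic carbon, ortho to a trifluoromethyl group, gives an at least 58-fold lower number from compound 1 to compound 3 (1.76 log units; beyond the scatter) in this assay. This shows that a change at this one position can separate a compound with a readable number from one without, which the two earlier compounds could not show because neither gave a number: the limit of > 100000 nM in this assay, at which 2 of the 3 values shown sit.

Compound 1 gives > 100000 nM, which is a limit and not a number, so the true step may be larger still.

The compounds shown carry only nitrile or hydrogen on this carbon, so it stays open whether activity depends on removing the nitrile or on having hydrogen there specifically. A methyl group, a fluorine atom or an amine at this position would help separate those two readings, and why the step occurs remains unknown.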